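Notes on the bromoalkyl ether, compound 4

The source may report more compounds than this note shows. Statements on the series, on what has been measured and on what is new or still open speak of the compounds shown alone.

Three measured compounds share one core and differ only at the amine nitrogen in the ring of the side chain. Compound 1 `COc1ccc(-c2coc3cc(OCCCSC(=S)N4CCN(Cc5ccccc5)CC4)ccc3c2=O)cc1` gives 43800 nM in a functional assay on MGC-803 cells (Homo sapiens) for inhibition, read by MTT assay, with a stated time of 48 h; on this read-out lower numbers stand for stronger inhibition and higher numbers for weaker inhibition. Compound 2 `CCN1CCN(C(=S)SCCCOc2ccc3c(=O)c(-c4ccc(OC)cc4)coc3c2)CC1` gives 54000 nM in this assay, and compound 3 `COc1ccc(-c2coc3cc(OCCCSC(=S)N4CCN(c5ccccn5)CC4)ccc3c2=O)cc1` gives 42000 nM. Compound 2 holds the highest of the three numbers, but its gaps to the other two, a 1.2-fold higher number from compound 1 to compound 2 (0.09 log units; within the scatter) and a 1.3-fold lower number from compound 2 to compound 3 (0.11 log units; within the scatter), both lie within the scatter, so no order among the three can be read. The third step, a 1.0-fold lower number from compound 1 to compound 3 (0.02 log units; within the scatter), is equally flat.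

Compound 4 `COc1ccc(-c2coc3cc(OCCCCCBr)ccc3c2=O)cc1` is the next entry. Against compound 2 the change is a group of 3 heavy atoms (2 carbon, 1 bromine; no ring) in place of a group of 11 heavy atoms (7 carbon, 2 nitrogen, 2 sulfur; one six-membered non-aromatic ring with 2 hetero atoms), on a saturated chain carbon, three bonds along the chain from an oxygen on an aromatic ring. All three measured steps exchange one substituent on the amine nitrogen of that ring; none removes the whole group, so none bears directly on this change. They show only that three different ends on the side chain left the number within the scatter. No direction can therefore be anchored in the measured steps, and the estimate stays near compound 2 with a wide range. Compound 4 is expected to give 60000 nM, between 20000 nM and 180000 nM. The step of a 1.1-fold higher number from compound 2 to compound 4 (0.05 log units; within the scatter) is thus estimated to stay within the scatter.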

Compound 4, half-maximal inhibitory concentration: > 100000 nM
Compound 4 ended at the assay's limit; the forecaster's own chance of this, stated with the estimate: 30%; middle value at least 1.6-fold (0.22 log units) from the limit.
By their numbers in this assay, from the lowest: compounds 3, 1 and 2 (each within the scatter of the next). At a limit, above all of these: compound 4.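

In this assay compound 4 gives > 100000 nM, which is a limit of the assay and not a number. Replacing the whole group with its six-membered non-aromatic ring by 2-bromoethyl, on a saturated chain carbon, three bonds along the chain from an oxygen on an aromatic ring, gives an at least 1.8-fold higher number from compound 2 to compound 4 (0.26 log units; that floor lies within the scatter), so only a floor is known for this step and that floor does not leave the scatter. The earlier steps exchanged only the substituent on the amine nitrogen in the ring, whereas this change removes the ring group entirely, and it brings no sign of stronger inhibition, with compound 4 alone sitting at the edge of the read-out: the limit of > 100000 nM in this assay, at which 1 of the 4 values shown sits.

On these data alone, how far compound 4 lies past its limit stays open, and with it whether the step truly leaves the scatter. Also open, as far as these compounds go, is whether the bromine or the absence of the ring group carries the result, a question that a chain ending in a hydroxyl or a simple amine at the same place would help to separate.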